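This account rests on a few compounds, and the source may have more. Where it says the series, first, only, none or still open, it means among the compounds named here.

In a functional assay on a cell-free system (plasma, Oryctolagus cuniculus) for inhibition, with stated times of 5 min, 1 min and 6 min (on this read-out lower numbers stand for stronger inhibition and higher numbers for weaker inhibition), compound 1 `CCOC(=O)c1[nH]c(-c2cccc(C#N)c2)nc1C` gives > 30000 nM, which is a limit of the assay and not a number. Compound 2 `C=CCOn1c(-c2cccc(C#N)c2)nc(C)c1C(=O)OCC` carries allyloxy in place of hydrogen on an aromatic nitrogen and gives 5860 nM. Within the data shown here, compound 3 `CCOC(=O)c1c(C)nc(-c2cccc(C#N)c2)n1OCCCO` carries 3-hydroxypropoxy there instead and gives 11400 nM, a number within the scatter of the one for compound 2. Adding either group mattered, as the measured steps show: an at least 5.1-fold lower number from compound 1 to compound 2 (0.70 log units; beyond the scatter) and an at least 2.6-fold lower number from compound 1 to compound 3 (0.42 log units; beyond the scatter).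

Compound 4 `CCOC(=O)c1c(C)nc(-c2cccc(C#N)c2)n1OCc1ccccc1F` has 2-fluorophenyl in place of 2-hydroxyethyl on a saturated chain carbon bound to an oxygen on an aromatic ring. The nearest guide is a 1.9-fold higher number from compound 2 to compound 3 (0.29 log units; within the scatter), a change at this same place that stayed within the scatter. Among the measured compounds shown here, no measured compound has a ring-bearing group here, so the uncertainty is wide. The expected change is small and slightly downward, a 1.8-fold lower number from compound 3 to compound 4 (0.24 log units; within the scatter), and no step beyond the scatter is expected. For compound 4 the estimate is 6500 nM, with an expected range from 2000 nM to 18000 nM.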

Compound 4, half-maximal inhibitory concentration: 8990 nM
The estimate for compound 4 lay 1.4-fold (0.14 log units) below the measured number; measured number inside the range.
By their numbers in this assay, from the lowest: compounds 2, 4 and 3 (each within the scatter of the next). At a limit, above all of these: compound 1.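

A ring is tolerated at this saturated chain carbon. In this assay, 2-fluorophenyl in place of 2-hydroxyethyl gives a 1.3-fold lower number from compound 3 to compound 4 (0.10 log units; within the scatter), and in place of vinyl it gives a 1.5-fold higher number from compound 2 to compound 4 (0.19 log units; within the scatter), so compounds 2, 3 and 4 cannot be told apart, although the new group has an aromatic ring and no hydrogen-bond donor. The lower number seen on replacing hydrogen on the aromatic nitrogen now holds for a third group, an at least 3.3-fold lower number from compound 1 to compound 4 (0.52 log units; beyond the scatter), a step readable only as a minimum because compound 1 stands at a limit: the limit of > 30000 nM in this assay, at which 1 of the 4 values shown sits.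

Open, as far as these compounds go, is whether a group carrying an amine or a carboxylic acid would move the number beyond the scatter. Also open, from the compounds shown here alone, is how plain benzyl would compare with 2-fluorobenzyl.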